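A few compounds are considered here, and "the series" means these few. Any claim that something is new, unique, unknown or untested is made for them only; others in the source may bear on it.

Measured so far in a physicochemical assay for solubility, read by HPLC, in phosphate buffer, measured as kinetic solubility, at pH 7.4 (a lower number here means a less soluble compound, a higher number a more soluble compound), for this series:
- compound 1 (`CCC(=O)c1cc(-c2ccc(Cl)cc2)n(-c2ccc(S(N)(=O)=O)cc2)c1`): 19500 nM
- compound 2 (`NS(=O)(=O)c1ccc(-c2cc(C(=O)C3CC3)nn2-c2ccc(Cl)cc2)cc1`): 25600 nM

The two values lie within the scatter of each other, so compound 2 does not stand apart from compound 1. Compound 3 (`CN(C(=O)c1cc(-c2ccc(S(N)(=O)=O)cc2)n(-c2ccc(Cl)cc2)n1)C1CC(F)(F)C1`) differs from compound 2 as follows ((3,3-difluorocyclobutyl)(methyl)amino in place of cyclopropyl on a carbonyl carbon), with (3,3-difluorocyclobutyl)(methyl)amino in place of cyclopropyl on a carbonyl carbon. Going by the values given here, no measured step covers this change, and the expectation rests on the structural change alone. A moderate downward step in this assay is expected (a 2.1-fold lower number from compound 2 to compound 3 (0.33 log units; beyond the scatter)) here. The estimated value for compound 3 is 12000 nM within an expected range (4000 nM to 30000 nM).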

Compound 3, solubility: 30900 nM
The estimate for compound 3 lay 2.6-fold (0.41 log units) below the measured number; the whole stated range lies below it.
By their numbers in this assay, from the lowest: compounds 1, 2 and 3 (each within the scatter of the next).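

In this assay, the exchange of cyclopropyl for (3,3-difluorocyclobutyl)(methyl)amino on a carbonyl carbon gives a 1.2-fold higher number from compound 2 to compound 3 (0.08 log units; within the scatter) and so leaves the two compounds indistinguishable. This first single-place step shows that this position accepts the change from cyclopropylcarbonyl to the much larger (3,3-difluorocyclobutyl)(methyl)carbamoyl without a readable separation in this read-out. No supporting data bear on why the values stay together. As far as these compounds go, whether a carboxylic acid or a simple dimethylamino group on this carbonyl carbon would also stay level remains open. Going by these compounds alone, the single step also cannot separate the contribution of the methyl from that of the 3,3-difluorocyclobutyl ring.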